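This account rests on a few compounds, and the source may have more. Where it says the series, first, only, none or still open, it means among the compounds named here.

Compound 1 `COc1ccc(C(O)c2cn(CCCO)nn2)c(OC)c1OC`: in a functional assay on B16 cells (Mus musculus) for cytotoxicity, read by MTT assay, with a stated time of 48 h (on this read-out lower numbers stand for stronger inhibition and higher numbers for weaker inhibition), compound 1 gives > 100000 nM, which is a limit of the assay rather than a number.
Compound 2 `Cc1ccc(C(O)c2cn(CC3COC(C)(C)O3)nn2)cc1`: compound 2 gives > 100000 nM, again a limit.
Compound 3 `COc1ccc(-c2cn(C[C@H]3COC(C)(C)O3)nn2)c(OC)c1OC`: compound 3 gives > 100000 nM, also a limit.

On the numbers shown, compound 2 cannot be placed above or below the others: its own value is a limit, and the two further values are limits as well, so that all three sit at the same point, (the limit of > 100000 nM in this assay, at which 3 of the 3 values shown sit). Within the data shown here, no step between measured compounds can be read from such values, and none is given.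

Compound 4 `Cc1ccc(C(O)c2cn(Cc3ccccc3)nn2)cc1` differs from compound 2 in one place: phenyl in place of 2,2-dimethyl-1,3-dioxolan-4-yl on a saturated chain carbon bound to an aromatic nitrogen. Since every measured value is a limit, the data offer no direction for this change in this assay, and the step expected is none beyond the scatter; the most likely outcome is that compound 4 also comes back as a limit.

Compound 4 is therefore expected to give about 150000 nM in this assay, with a range from 30000 nM to 1000000 nM. The step that this estimate means is expected to be a step that the limit leaves unreadable from compound 2 to compound 4.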

Compound 4, half-maximal inhibitory concentration: > 100000 nM
Compound 4 ended at the assay's limit (the forecaster's own chance of this, stated with the estimate: 80%); the middle value is on the limit's open side.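

No step can be read from compound 2 to compound 4, since in this assay both compounds stand at the same limit and not at a number: the limit of > 100000 nM in this assay, at which 4 of the 4 values shown sit.

The compounds shown leave open how these four rank against one another, and which structural change, if any, would bring a value off this limit.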